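Dropping the Phenyl Ring: A Step into Uncharted Ground

This account rests on a few compounds, and the source may have more. Where it says the series, first, only, none or still open, it means among the compounds named here.

For the measured compounds named here, compound 2 `CCOc1cc(NC(=O)CCCCCC(=O)Nc2cc(-c3ccccc3)ccc2N)cc2c1OCC([N+](=O)[O-])=C2` is the only compound here with a numeric result: in a functional assay on MCF7 cells (Homo sapiens) for antiproliferative activity, read by MTT assay, with a stated time of 48 h (a lower number here means a stronger inhibitor of growth, a higher number a weaker inhibitor of growth), compound 2 gives 7030 nM. Compound 1 `CCOc1cc(NC(=O)CCCCCC(=O)Nc2cc(-c3ccc(C)s3)ccc2N)cc2c1OCC([N+](=O)[O-])=C2` reached only a limit of this assay, > 20000 nM (the limit of > 20000 nM in this assay, at which 1 of the 2 values shown sits). Going by the values given here, the single measured step, an at least 2.8-fold lower number from compound 1 to compound 2 (0.45 log units; beyond the scatter), exchanged one aromatic group for another. Compound 3 `CCOc1cc(NC(=O)CCCCCC(=O)Nc2ccccc2N)cc2c1OCC([N+](=O)[O-])=C2` differs from compound 2 by hydrogen in place of phenyl on an aromatic carbon. Among the compounds with values here, no measured step removes this group entirely, so the direction is uncertain; compound 3 is expected at 10000 nM, within 3000 nM to 30000 nM, which means an expected step of a 1.4-fold higher number from compound 2 to compound 3 (0.15 log units; within the scatter) that may stay within scatter.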

Compound 3, concentration for 50% growth inhibition: 19500 nM
The estimate for compound 3 lay 2.0-fold (0.29 log units) below the measured number; low and high end bracket the measured number.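

Replacing the phenyl group with hydrogen gives a modest step, a 2.8-fold higher number from compound 2 to compound 3 (0.44 log units; beyond the scatter), in this assay, so at this aromatic carbon, para to an amino group, phenyl gives stronger growth inhibition than a bare hydrogen. Compound 1 stands at a limit of this assay, so the step of an at least 1.0-fold lower number from compound 1 to compound 3 (0.01 log units; that floor lies within the scatter) cannot be read beyond that floor: the limit of > 20000 nM in this assay, at which 1 of the 3 values shown sits.

As far as these compounds go, whether the 5-methylthiophen-2-yl group offers any gain over hydrogen therefore stays unknown. The compounds shown also leave open whether a pyridine ring or a methyl group on this carbon would match phenyl.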